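Swapping 4-chlorophenyl for ethyl on the side chain

The source may hold more compounds than are shown below. What is called first, only, known or untested is meant among the compounds shown, and "the series" means these compounds.

Compound 1 `[O-][n+]1nc(NCOCc2ccc(Cl)cc2)[n+]([O-])c2ccccc21`: 5100 nM
Compound 2 `COCNc1n[n+]([O-])c2ccccc2[n+]1[O-]`: 4270 nM

For the measured compounds named here, in a functional assay on PC-3 cells (Homo sapiens) for cytotoxicity, read by MTT assay, with a stated time of 72 h (a lower number here means a stronger inhibitor, a higher number a weaker inhibitor), compound 1 gives 5100 nM, which cannot be told apart from the value of compound 2, the only other compound measured. Compound 3 `CCCOCNc1n[n+]([O-])c2ccccc2[n+]1[O-]` differs from compound 1 in one group: ethyl in place of 4-chlorophenyl on a saturated chain carbon bound to an oxygen on a saturated carbon. Going by the values given here, one measured step bears on this change: a 1.2-fold lower number from compound 1 to compound 2 (0.08 log units; within the scatter). There, hydrogen took the place of the same 4-chlorophenyl, and the result stayed within the scatter. Ethyl is therefore expected to cause no step beyond the scatter in this assay either. The expected change is a 1.1-fold lower number from compound 1 to compound 3 (0.04 log units; within the scatter). Compound 3 is estimated at 4700 nM, within a range of 2400 nM to 9000 nM.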

Compound 3, half-maximal inhibitory concentration: 7400 nM
Estimate against measurement, compound 3: 1.6-fold (0.20 log units) below; the measured number falls inside the stated range.
By their numbers in this assay, from the lowest: compounds 2, 1 and 3 (each within the scatter of the next).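

In this assay the change to ethyl from 4-chlorophenyl gives a 1.5-fold higher number from compound 1 to compound 3 (0.16 log units; within the scatter) and the change to ethyl from hydrogen gives a 1.7-fold higher number from compound 2 to compound 3 (0.24 log units; within the scatter) in the same test. Ethyl therefore joins hydrogen and 4-chlorophenyl as a third group at this place on the side chain, and the steps between it and the other two do not separate it from them. Nothing measured here offers an explanation for this result. Still open, going by these compounds, is whether an amine, a carboxylic acid or a longer chain at this place would produce a step beyond the scatter.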